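The compounds below may be only part of what the source reports. "The series", "measured", "known", "first", "only" and "open" are said of these compounds alone.

Measured in an ADME assay on HepG2 cells (Homo sapiens) for cytotoxicity, read by MTT assay, with a stated time of 24 h; a lower number here means that less compound is tolerated, a higher number that more compound is tolerated:
- compound 1 `Cc1ccc(-c2cn(-c3ccnc4cc(Cl)ccc34)nn2)cc1`: 352000 nM
- compound 2 `O=C(OCCCc1cn(-c2ccnc3cc(Cl)ccc23)nn1)c1ccc(C(F)(F)F)cc1`: > 2170000 nM (a limit)
- compound 3 `CC(C)(C)c1ccc(C(=O)OCCCc2cn(-c3ccnc4cc(Cl)ccc34)nn2)cc1`: > 2230000 nM (a limit)

Of these three, only compound 1 has an actual number, 352000 nM. Compound 2 gives > 2170000 nM, which is a limit of the assay. Compound 3 gives > 2230000 nM, also a limit.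

Compound 4 `CCN(CC)Cc1cn(-c2ccnc3cc(Cl)ccc23)nn1`, not yet measured, carries (diethylamino)methyl in place of 4-methylphenyl on an aromatic carbon. For the measured compounds named here, the one measured step, a step that the two limits leave unreadable from compound 2 to compound 3, concerns a different change and offers no size to borrow. Going by the values given here, the only number to start from is that of compound 1, 352000 nM, so no change beyond the usual scatter is expected in this assay. The expected step is a 1.4-fold higher number from compound 1 to compound 4 (0.15 log units; within the scatter). For compound 4 the estimated value is 500000 nM, with an expected range from 120000 nM to 2000000 nM.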

Compound 4, half-maximal cytotoxic concentration: 1850000 nM
Estimate against measurement, compound 4: 3.7-fold (0.57 log units) below, and the stated range covers the measured number.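

In this assay, (diethylamino)methyl in place of 4-methylphenyl on the same aromatic carbon gives a 5.3-fold higher number from compound 1 to compound 4 (0.72 log units; beyond the scatter) and so shows that this position is sensitive to what it carries. The earlier pair gave no such size, as the step from compound 2 to compound 3 cannot be read between two limits. No measurement shown explains the new step. The change removes a carbon-only aromatic ring and brings in a nitrogen at once, and the compounds shown do not tell which of the two matters. A plain pentyl chain or a piperidine at this position would help to separate them.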